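From Chlorobenzyl to Phenylethyl: Estimating Compound 3

The compounds below may be only part of what the source reports. "The series", "measured", "known", "first", "only" and "open" are said of these compounds alone.

In a functional assay on CHO-K1 cells for antagonist activity at adenosine receptor A1 (Homo sapiens), read by a beta-galactosidase reporter and cAMP accumulation, with stated times of 15 min and 6 h (a lower number here means a stronger inhibitor, a higher number a weaker inhibitor), compound 2 `Cc1ccc(-c2nc(N)c3cc(Cc4ccccc4Cl)sc3n2)o1` gives 26.1 nM, the lowest of the two numbers measured; its nearest neighbour, compound 1 `Cc1ccc(-c2nc(N)c3cc(CCc4ccccc4)sc3n2)o1`, gives 2780 nM. Among the compounds with values here, that pair forms the only measured step, a 110-fold lower number from compound 1 to compound 2 (2.03 log units; beyond the scatter), which altered the link and the chlorine together. Compound 3 `Cc1ccc(-c2nc(N)c3cc(C(C)c4ccccc4)sc3n2)o1` differs from compound 2 by 1-phenylethyl in place of 2-chlorobenzyl on an aromatic carbon. Within the data shown here, since the one measured step mixed two alterations, it bears only loosely on this change, which removes the chlorine while keeping a single-carbon link. For compound 3 a moderate rise is expected, a 7.7-fold higher number from compound 2 to compound 3 (0.88 log units; beyond the scatter), with an estimate of 200 nM between 40 nM and 1000 nM.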

Compound 3, inhibition constant: 439 nM
Estimate against measurement, compound 3: 2.2-fold (0.34 log units) below; measured number inside the range.
By their numbers in this assay, from the lowest: compound 2; then compound 3; then compound 1.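

In this assay, the step of a 17-fold higher number from compound 2 to compound 3 (1.23 log units; beyond the scatter) shows that this position, next to the ring sulfur, responds strongly to 1-phenylethyl in place of 2-chlorobenzyl. The step of a 6.3-fold lower number from compound 1 to compound 3 (0.80 log units; beyond the scatter) shows that 1-phenylethyl in place of phenethyl also moves the number, though by less, with no chlorine on either side. Nothing available explains either step. The compounds shown leave open how plain benzyl would stand, and so whether the chlorine or the methyl on the link carbon accounts for the larger step.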